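The source may report more compounds than this note shows. Statements on the series, on what has been measured and on what is new or still open speak of the compounds shown alone.

Measured compounds in a functional assay on A549 cells (Homo sapiens) for inhibition, read by sulforhodamine B assay, with a stated time of 48 h; on this read-out higher numbers stand for weaker inhibition of growth and lower numbers for stronger inhibition of growth:
- compound 1, `COC(=O)[C@@]1(C)CCC=C2[C@@H]1CC[C@@H](C)[C@]2(C)Cc1c[nH]c2ccc(F)cc12`, gives 6200 nM
- compound 2, `COC(=O)[C@@]1(C)CCC=C2[C@@H]1CC[C@@H](C)[C@]2(C)Cc1c(C)[nH]c2ccc(F)cc12`, gives 15000 nM
- compound 3, `COC(=O)[C@@]1(C)CC[C@@H]2C3=C1CC[C@@H](C)[C@]3(C)Cc1c2[nH]c2ccccc12`, gives 4600 nM

Compound 1 and compound 2 differ in one place: methyl in place of hydrogen on an aromatic carbon. In this assay this gave a 2.4-fold higher number from compound 1 to compound 2 (0.38 log units; beyond the scatter). Compound 3 carries a different core; the difference between the core of compound 3 and the core of compound 1 is not broken down here. Compound 3 and compound 1 give numbers within the usual scatter of each other, while compound 2 stands beyond the scatter from both.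

Compound 4, `COC(=O)[C@@]1(C)CC[C@@H]2C3=C1CC[C@@H](C)[C@]3(C)Cc1c2[nH]c2c(C)cccc12`, is not yet measured. It differs from compound 3 by methyl in place of hydrogen on an aromatic carbon. This is the same kind of change as that from compound 1 to compound 2, but not the same: there the methyl entered on a five-membered aromatic ring with one nitrogen, next to the ring nitrogen and next to the ring atom that bears a large group; here it enters on a six-membered aromatic ring of carbon only, part of a fused or bridged system of five rings, ortho to a fused ring and meta to a fused ring. For the measured compounds named here, only one earlier example of a methyl for hydrogen exchange exists, and at a different place, so the expectation rests loosely on it. A step of a 1.5-fold higher number from compound 3 to compound 4 (0.18 log units; within the scatter) is expected in this assay, a somewhat smaller move in the same direction, because a 2.4-fold higher number from compound 1 to compound 2 (0.38 log units; beyond the scatter) was modest and the place differs. Compound 4 is estimated at 7000 nM, expected between 3000 nM and 20000 nM.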

Compound 4, concentration for 50% growth inhibition: 16000 nM
Compound 4: the middle estimate sits 2.3-fold (0.36 log units) below what was measured; low and high end bracket the measured number.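

In this assay, methyl in place of hydrogen on an aromatic carbon gave a 3.5-fold higher number from compound 3 to compound 4 (0.54 log units; beyond the scatter), so growth inhibition also weakened on this core. Set beside the earlier case, the two steps run in the same direction and do not differ beyond the scatter: the same change on two cores in this assay, a 2.4-fold higher number (0.38 log units; beyond the scatter) from compound 1 to compound 2 and a 3.5-fold higher number (0.54 log units; beyond the scatter) from compound 3 to compound 4, 1.4-fold (0.16 log units) apart, within the scatter of two such steps. For the compounds shown here, this supports carrying the direction and rough size of the change between these two cores, but it rests on only two pairs, with the methyl at a different place on each core, so the effect of the core cannot be separated from that of the place, and no rule for the wider series follows.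

The compounds shown leave open whether a group other than methyl at this place on the six-membered aromatic ring, such as a hydroxyl, a methoxy or an amine, would also give a higher number. Also open, going by these compounds, is how either core would respond if a carboxylic acid or an amide stood in place of the methyl ester shared by all four compounds.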